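A few compounds are considered here, and "the series" means these few. Any claim that something is new, unique, unknown or untested is made for them only; others in the source may bear on it.

Compound 1 `CCS(=O)(=O)Nc1ccc(NC(=O)c2cccc(C(F)(F)F)c2)cc1C` and compound 2 `Cc1cc(NC(=O)c2cccc(C(F)(F)F)c2)ccc1NS(=O)(=O)C(F)(F)F` share one core, while compound 3 `CCS(=O)(=O)Nc1ccc(NC(=O)c2ccc(Cl)cc2)cc1Cl` and compound 4 `O=C(Nc1ccc(NS(=O)(=O)C(F)(F)F)c(Cl)c1)c1ccc(Cl)cc1` share another; how the two cores differ is not broken down here. In an ADME assay on HEK293 cells (Homo sapiens) for cytotoxicity, read by MTT assay, with a stated time of 48 h (a higher number here means a weaker inhibitor, a lower number a stronger inhibitor), compound 1 gives 210000 nM and compound 2 gives 131000 nM, a step of a 1.6-fold lower number from compound 1 to compound 2 (0.20 log units; within the scatter) that goes with the change (trifluoromethyl in place of ethyl on a sulfonyl sulfur). For compound 3 only a limit is known in this assay, namely > 250000 nM. That limit is the limit of > 250000 nM in this assay, at which 1 of the 3 values shown sits. Compound 4 carries the same kind of change on the other core, (trifluoromethyl in place of ethyl on a sulfonyl sulfur), and is not yet measured. The earlier step, a 1.6-fold lower number from compound 1 to compound 2 (0.20 log units; within the scatter), stayed within the scatter, so the expected step here is about an at least 1.1-fold lower number from compound 3 to compound 4 (0.05 log units; that floor lies within the scatter). On that basis compound 4 is estimated at 220000 nM, with a likely range from 120000 nM to 400000 nM.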

Compound 4, half-maximal inhibitory concentration: 191000 nM
The estimate for compound 4 lay 1.2-fold (0.06 log units) above the measured number, and the stated range covers the measured number.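

In this assay, placing trifluoromethyl in place of ethyl on the sulfonyl sulfur gives an at least 1.3-fold lower number from compound 3 to compound 4 (0.11 log units; that floor lies within the scatter). The value of compound 3, > 250000 nM, is a limit of the assay and not a number, so this step is only a floor. Set beside the earlier core, the result does not show that the change carries over with the same size: the same change on two cores in this assay, a 1.6-fold lower number (0.20 log units; within the scatter) from compound 1 to compound 2 and an at least 1.3-fold lower number (0.11 log units; that floor lies within the scatter) from compound 3 to compound 4; the limit leaves it open whether they differ

The compounds shown leave open how other groups on the sulfonyl sulfur, such as methyl, a longer chain like propyl, or an amine, would read in this assay. They also leave open whether this change would give a similar step on any further core.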